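A few compounds are considered here, and "the series" means these few. Any claim that something is new, unique, unknown or untested is made for them only; others in the source may bear on it.

Measured compounds:
Compound 1, `O=C(Nc1ccc(Sc2nc3ccccc3s2)cc1)c1cc(Br)cc(Br)c1O`: in an assay for inhibition of HSP60/HSP10 (Homo sapiens), with a stated time of 60 min (a higher number here means a weaker inhibitor, a lower number a stronger inhibitor), compound 1 gives 4700 nM.
Compound 2, `COc1c(Br)cc(Br)cc1C(=O)Nc1ccc(Sc2nc3ccccc3s2)cc1`: in this assay compound 2 reaches only the limit of the assay, > 100000 nM.
Compound 3, `O=C(Nc1cccc(Cl)c1)c1cccc(Br)c1O`: in this assay compound 3 also reaches only the limit of the assay, > 100000 nM.

Compound 1 and compound 2 differ in a single place: methyl in place of hydrogen on an oxygen on an aromatic ring. That change carries an at least 21-fold higher number from compound 1 to compound 2 (1.32 log units; beyond the scatter). The true size of this step is not fully known, because compound 2 sits at the limit of > 100000 nM in this assay, at which 2 of the 3 values shown sit; the step could be larger than the number given.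

Compound 3 shares with compound 1 the amide link and the hydroxy group on the ring that bears the bromine, but its two rings differ in several places from those of compound 1, and the difference between the two cores is not broken down here. Compound 3 gives only a limit, so its own potency can only be said to be weak.

Compound 4, `COc1c(Br)cccc1C(=O)Nc1cccc(Cl)c1`, is not yet measured. It stands to compound 3 as compound 2 stands to compound 1: methyl in place of hydrogen on an oxygen on an aromatic ring. The two places read word for word the same, so this is the same change. In compound 1 the change removed measurable inhibition. Compound 3 already sits at the limit, so there is no measurable inhibition left to lose; for compound 4 an outcome at or beyond the limit is therefore expected, an estimated step that the limit leaves unreadable from compound 3 to compound 4. The estimate for compound 4 is 150000 nM, with an expected range from 100000 nM to 500000 nM.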

Compound 4, half-maximal inhibitory concentration: > 100000 nM
Compound 4: no number, only a limit (the forecaster's own chance of this, stated with the estimate: 95%); the middle value does not contradict the limit.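

In this assay compound 4 gives > 100000 nM, which is a limit of the assay and not a number. No size can be read for the step between compound 3 and compound 4, because both compounds sit at a limit: the limit of > 100000 nM in this assay, at which 3 of the 4 values shown sit.

The compounds shown leave open whether hydroxy to methoxy changes inhibition at all on the core of compound 3.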